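The compounds below may be only part of what the source reports. "The series", "measured", "known", "first", "only" and "open" are said of these compounds alone.

Going by the values given here, in a functional assay on A549 cells (Homo sapiens) for inhibition, read by MTT assay, with a stated time of 48 h (on this read-out lower numbers stand for stronger inhibition and higher numbers for weaker inhibition), compound 2 `Brc1ccc2[nH]cc(C(c3c[nH]c4ccc(Br)cc34)C3CCCCC3)c2c1` gives 5500 nM, the lower of the two numbers known so far, while compound 1 `COc1ccc(C(c2c[nH]c3ccc(Br)cc23)c2c[nH]c3ccc(Br)cc23)c(OC)c1` gives 100000 nM. Compound 3 `O=[N+]([O-])c1ccc(C(c2c[nH]c3ccc(Br)cc23)c2c[nH]c3ccc(Br)cc23)cc1` differs from compound 2 by one change: 4-nitrophenyl in place of cyclohexyl on a saturated chain carbon bound to two aromatic carbons. Among the compounds with values here, the one measured step bearing on this, an 18-fold lower number from compound 1 to compound 2 (1.26 log units; beyond the scatter), put cyclohexyl in place of 2,4-dimethoxyphenyl, so the return of a substituted phenyl points to a higher number in this assay, of uncertain size. The expected change is a 3.6-fold higher number from compound 2 to compound 3 (0.56 log units; beyond the scatter). For compound 3 the estimated value is 20000 nM, with an expected range of 5000 nM to 100000 nM.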

Compound 3, half-maximal inhibitory concentration: 5500 nM
Compound 3: the middle estimate sits 3.6-fold (0.56 log units) above what was measured; the range from low to high includes it.
By their numbers in this assay, from the lowest: compounds 2 and 3 (each within the scatter of the next); then compound 1.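

In this assay, 4-nitrophenyl in place of cyclohexyl on the saturated chain carbon gives no change at the digits printed from compound 2 to compound 3 (within the scatter) and so shows that an aromatic ring at this position does not by itself bring a high number. 4-nitrophenyl in place of 2,4-dimethoxyphenyl gives an 18-fold lower number from compound 1 to compound 3 (1.26 log units; beyond the scatter) and so places the difference in what the phenyl ring carries, not in the ring alone. The data offer no explanation for either step. Which of the nitro and methoxy groups matters remains open. So does how plain phenyl, 4-methoxyphenyl or 4-aminophenyl would read at this position.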